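The source may hold more compounds than are shown below. What is called first, only, known or untested is meant among the compounds shown, and "the series" means these compounds.

Working notes on a small series tested in a functional assay on the whole organism (strain Wister albino) for inhibition, with Rattus norvegicus as the target, read by paw edema, with stated times of 1 h and 4 h, at a dose of 50 mg/kg by the intraperitoneal route; on this read-out lower numbers stand for less inhibition and higher numbers for more inhibition at the one dose given (going by the name of the read-out). Compound 1 `CN1C[C@@H](c2ccc(F)cc2)[C@@]2(Cc3ccccc3C2=O)[C@@]12C(=O)Nc1ccccc12` gives 21.8%. Compound 2 `CN1C(=O)[C@@]2(c3ccccc31)N(C)C[C@@H](c1ccc(F)cc1)[C@@]21Cc2ccccc2C1=O` gives 25.5%. Compound 3 `COc1ccc([C@@H]2CN(C)[C@]3(C(=O)N(C)c4ccccc43)[C@]23Cc2ccccc2C3=O)cc1` gives 3.8%, the lowest of the three numbers, with both gaps to the others beyond the scatter.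

Two single changes connect the measured compounds. The change hydrogen in place of methyl on an amide-type nitrogen in a ring produced a number 3.7 percentage points lower from compound 2 to compound 1 (within the scatter). The change methoxy in place of fluoro on an aromatic carbon produced a number 21.7 percentage points lower from compound 2 to compound 3 (beyond the scatter), and this is also how the core of compound 3 differs from the core of compound 2.

Compound 4 `COc1ccc([C@@H]2CN(C)[C@]3(C(=O)Nc4ccccc43)[C@]23Cc2ccccc2C3=O)cc1` is not yet measured. It differs from compound 3 by hydrogen in place of methyl on an amide-type nitrogen in a ring. The place is the same word for word as in the change from compound 2 to compound 1, so this is the same change made on the other core; it occurs twice among the compounds shown.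

The expectation for compound 4 rests on compound 3 at 3.8% and on the earlier step of a number 3.7 percentage points lower from compound 2 to compound 1 (within the scatter), which stayed within the scatter. Set beside that earlier step, the expected step is a number 0.8 percentage points lower from compound 3 to compound 4 (within the scatter). The estimate for compound 4 in this assay is 3%, with a range from -6% to 14%. One measured pair is a thin basis for this change, and nothing here tests it on the core of compound 3.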

Compound 4, a percentage reported as inhibition, in the whole organism at one dose (the size of the read-out at that dose, not a potency): 21.8%
Estimate against measurement, compound 4: 18.8 percentage points below; the whole stated range lies below it.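

Hydrogen in place of methyl on an amide-type nitrogen in a ring gave a number 18 percentage points higher from compound 3 to compound 4 (beyond the scatter), so in this assay the size of this step does not carry from one core to the other: the same change on two cores in this assay, a number 3.7 percentage points lower (within the scatter) from compound 2 to compound 1 and a number 18 percentage points higher (beyond the scatter) from compound 3 to compound 4, 21.7 percentage points apart, beyond the scatter of two such steps

Methoxy in place of fluoro on an aromatic carbon gave no change at the digits printed from compound 1 to compound 4 (within the scatter), so that change also does not carry over, and its step depends on whether the amide-type nitrogen bears methyl or hydrogen: the same change on two cores in this assay, a number 21.7 percentage points lower (beyond the scatter) from compound 2 to compound 3 and no change at the digits printed (within the scatter) from compound 1 to compound 4, 21.7 percentage points apart, beyond the scatter of two such steps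

Among the compounds shown here, these four compounds show that the two changes cannot be treated as independent steps here, but they do not show why, and with only one pair per core they give no rule for any other core.

The compounds shown leave open whether the low value of compound 3 at 3.8% is specific to methoxy with methyl on the amide-type nitrogen, or whether other pairings would also give such a value. An ethyl group or a longer chain on that nitrogen, or a chloro or hydroxy group in place of fluoro or methoxy on the aromatic carbon, would show whether the same dependence extends beyond these four compounds.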